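Working notes on amide-side variation in a glutathione S-transferase Mu 2 series

The source may report more compounds than this note shows. Statements on the series, on what has been measured and on what is new or still open speak of the compounds shown alone.

Measured so far:
Compound 1, `O=C(CCC(=O)OCCCCCCSc1ccc([N+](=O)[O-])c2nonc12)Nc1ccc(C(F)(F)F)cc1`, in an assay on isolated protein for inhibition of glutathione S-transferase Mu 2 (Homo sapiens), with a stated time of 10 min; on this read-out lower numbers stand for stronger inhibition and higher numbers for weaker inhibition: 90 nM
Compound 2, `CCN(CC)CCCNC(=O)CCC(=O)OCCCCCCSc1ccc([N+](=O)[O-])c2nonc12`, in this assay: 440 nM

Compound 2 carries the higher of the two numbers. Among the compounds with values here, the only step reaching it is a 4.9-fold higher number from compound 1 to compound 2 (0.69 log units; beyond the scatter), a change on the amide-type nitrogen in which an aryl group gives way to an amine-bearing chain.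

Compound 3, `O=C(CCC(=O)OCCCCCCSc1ccc([N+](=O)[O-])c2nonc12)NCCN1CCCC1`, is the next candidate. It differs from compound 2 by pyrrolidin-1-yl in place of (diethylamino)methyl on a saturated chain carbon, two bonds along the chain from an amide-type nitrogen. Within the data shown here, only one measured step exists, a 4.9-fold higher number from compound 1 to compound 2 (0.69 log units; beyond the scatter), and it compares an aryl substituent with an amine-bearing chain; no measured pair compares two amine-bearing chains with each other. The change from compound 2 to compound 3 keeps the chain, its amide-type nitrogen and the single hydrogen-bond acceptor counted in the leaving and entering groups, so nothing measured points to a shift of the number in either direction. The expected step is therefore a 1.1-fold lower number from compound 2 to compound 3 (0.04 log units; within the scatter), within the scatter. Compound 3 is estimated at 400 nM, with a range from 150 nM to 1100 nM.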

Compound 3, half-maximal inhibitory concentration: 200 nM
The estimate for compound 3 lay 2.0-fold (0.30 log units) above the measured number, within the range that was stated.
By their numbers in this assay, from the lowest: compound 1; then compound 3; then compound 2.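

In this assay, pyrrolidin-1-yl in place of (diethylamino)methyl on a saturated chain carbon, two bonds along the chain from an amide-type nitrogen, gives a 2.2-fold lower number from compound 2 to compound 3 (0.34 log units; beyond the scatter). This shows that the number responds to a change from one amine-bearing chain to another, a comparison the earlier pair could not offer. Even so, 2-(pyrrolidin-1-yl)ethyl in place of 4-(trifluoromethyl)phenyl on the amide-type nitrogen gives a 2.2-fold higher number from compound 1 to compound 3 (0.35 log units; beyond the scatter), so compound 1 keeps the lowest number of the three, and no measurement at hand accounts for either step.

Read one bond further out, the change from compound 2 to compound 3 is 3-(diethylamino)propyl to 2-(pyrrolidin-1-yl)ethyl, so the ring and the chain length change together and their contributions cannot be separated from these compounds alone. A 2-(diethylamino)ethyl or 3-(pyrrolidin-1-yl)propyl group on the amide-type nitrogen would pull the two apart, while a chain ending in a morpholin-4-yl group or a carboxylic acid would test how far the number depends on the amine itself.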